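Exchanging the Amide Amine on a Shared Core

A few compounds are considered here, and "the series" means these few. Any claim that something is new, unique, unknown or untested is made for them only; others in the source may bear on it.

Compound 1 `CN(Cc1ccccc1)C(=O)C1CCN(C(=O)c2ccc(S(C)(=O)=O)c([N+](=O)[O-])c2)CC1`: > 60000 nM
Compound 2 `CC(C)N(C(=O)CNC(=O)c1ccc(S(C)(=O)=O)c([N+](=O)[O-])c1)C(C)C`: > 60000 nM
Compound 3 `CC(C)N(C(=O)CCNC(=O)c1ccc(S(C)(=O)=O)c([N+](=O)[O-])c1)C(C)C`: > 60000 nM

All three compounds share a core and were tested in an assay on isolated protein for inhibition of thyroid hormone receptor beta (Homo sapiens), read by fluorescence polarization; on this read-out lower numbers stand for stronger inhibition and higher numbers for weaker inhibition. Compound 2 gives there only a limit of the assay, > 60000 nM, not a number. Compound 1 and compound 3 stand likewise; in fact (the limit of > 60000 nM in this assay, at which 3 of the 3 values shown sit). Among the measured compounds shown here, no measured step therefore separates any pair, and nothing shows which change moves the read-out. Compound 4 `CN1CCN(C(=O)CNC(=O)c2ccc(S(C)(=O)=O)c([N+](=O)[O-])c2)CC1` differs from compound 2 in one place: 4-methylpiperazin-1-yl in place of diisopropylamino on a carbonyl carbon. For the measured compounds named here, with every number so far at the limit, no step beyond the scatter is expected in this assay, a number no higher from compound 2 to compound 4 (the limit leaves the size open). Compound 4 is thus estimated at 60000 nM, between 15000 nM and 200000 nM, most likely once more only a limit.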

Compound 4, half-maximal inhibitory concentration: > 60000 nM
Compound 4: only a limit was reported (the forecaster's own chance of this, stated with the estimate: 85%); the middle value sits exactly at the limit.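

Compound 2 and compound 4 both give only a limit of the assay, so no step between them can be read: the limit of > 60000 nM in this assay, at which 4 of the 4 values shown sit.

The compounds shown leave open whether exchanging the amide amine on the shared core moves the read-out at all.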